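Cyclopentyl for Pentyl on the Amide Nitrogen

A few compounds are considered here, and "the series" means these few. Any claim that something is new, unique, unknown or untested is made for them only; others in the source may bear on it.

Compound 1 `CNC(=O)CC1CCc2cc(OC)c(OC)cc21` and compound 2 `CCCCCNC(=O)CC1CCc2cc(OC)c(OC)cc21` share one core and differ only in the group on the amide nitrogen. In a functional assay on the whole organism (strain Wistar) for inhibition, with Rattus norvegicus as the target, read by paw edema, with stated times of 60 min and 1 h, at a dose of 100 mg/kg by the oral route (on this read-out higher numbers stand for more inhibition at the one dose given (going by the name of the read-out) and lower numbers for less inhibition), compound 1 gives 15.6%, and compound 2 gives 34.4%. Compound 2 therefore stands highest of the two numbers; the step of a number 18.8 percentage points higher from compound 1 to compound 2 (beyond the scatter) came from butyl in place of hydrogen on a saturated chain carbon bound to an amide-type nitrogen.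

Compound 3 `COc1cc2c(cc1OC)C(CC(=O)NC1CCCC1)CC2` has not been measured. It differs from compound 2 by cyclopentyl in place of pentyl on an amide-type nitrogen. Within the data shown here, no measured step exchanges an open chain for a ring of the same count. Among the measured compounds shown here, the one step known, a number 18.8 percentage points higher from compound 1 to compound 2 (beyond the scatter), concerns the same nitrogen, but it only shows what adding a chain there did, not what closing that chain into a ring does. With nothing bearing directly on the change, the expected step to compound 3 is a number 0.4 percentage points lower from compound 2 to compound 3 (within the scatter), within the scatter. Compound 3 is estimated at 34% in this assay, with a range from 20% to 48%.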

Compound 3, a percentage reported as inhibition, in the whole organism at one dose (the size of the read-out at that dose, not a potency): 40.6%
Beside the measured number, compound 3's estimate is 6.6 percentage points below it; the range from low to high includes it.
By their numbers in this assay, from the lowest: compound 1; then compounds 2 and 3 (each within the scatter of the next).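

On the amide nitrogen, closing the open chain into a ring with the same count of carbons gives a number 6.2 percentage points higher from compound 2 to compound 3 (within the scatter) in this assay, so pentyl and cyclopentyl cannot be told apart by this read-out. The earlier compounds shown here showed only that a pentyl chain reads differently from a methyl group, whereas the new result shows that an open chain is not required at this position. The ring also stands clear of the methyl group, with a number 25 percentage points higher from compound 1 to compound 3 (beyond the scatter) as the step, and among these three compounds both larger groups therefore read beyond the scatter of methyl, with none going against this. Nothing measured here explains these numbers.

On these data alone, it remains open how much of the difference from methyl depends on the size of the group, which a propyl chain, a cyclopropyl ring or a cyclohexyl ring would help to test. A tetrahydropyranyl ring, which carries an oxygen atom, would show whether the ring must be made of carbon only.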